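Exchanging a carboxy for a phenyl on the same chain

The source may hold more compounds than are shown below. What is called first, only, known or untested is meant among the compounds shown, and "the series" means these compounds.

Compound 1 `CCCc1nc(C)c2c(C)nn(C)c(=O)n12`, compound 2 `CCCc1nc(C)c2c(C)nn(CC(=O)O)c(=O)n12` and compound 3 `C=CCn1ncc2c(C)nc(C(C)(C)C)n2c1=O` share one read-out, a functional assay for inhibition, with Homo sapiens as the target; on this read-out lower numbers stand for stronger inhibition and higher numbers for weaker inhibition. In this assay compound 1 reaches only the limit of the assay, > 48000 nM. In this assay compound 2 likewise stops at the limit, > 48000 nM, so no number is known for it. In this assay compound 3 also stops at the limit, > 48000 nM. Within the data shown here, the step that the two limits leave unreadable from compound 1 to compound 2 therefore cannot be read, as the limit of > 48000 nM in this assay, at which 3 of the 3 values shown sit, shows; all three values sit at the same limit and give no order among the compounds.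

Compound 4 `CCCc1nc(C)c2c(C)nn(Cc3ccccc3)c(=O)n12` is the one still to be measured. It differs from compound 2 in one place: phenyl in place of carboxy on a saturated chain carbon bound to an aromatic nitrogen. Among the measured compounds shown here, no measured step bears on this change; the only measured step, a step that the two limits leave unreadable from compound 1 to compound 2, is itself unreadable. Every value shown is a limit, so the expectation for compound 4 rests on that alone, and no direction is supported. The expected step of an at least 1.2-fold lower number from compound 2 to compound 4 (0.07 log units; that floor lies within the scatter) is therefore set near zero. Compound 4 is estimated to give 40000 nM in this assay, within 5000 nM and 100000 nM, most probably again only a limit.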

Compound 4, half-maximal inhibitory concentration: > 48000 nM
Compound 4 was reported as a limit; the forecaster's own chance of this, stated with the estimate: 70%; at least 1.2-fold (0.07 log units) between middle value and limit.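

In this assay compound 4 also gives only a limit, > 48000 nM. The steps to compound 4 from compound 1 and from compound 2 therefore cannot be read, and the compounds fall in no order: the limit of > 48000 nM in this assay, at which 4 of the 4 values shown sit. Still open, going by these compounds, is whether any compound of this kind gives a real number in this assay, and how hydrogen, carboxy and phenyl on this chain rank against one another.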